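Mirror-Image Change at One Stereocentre in a GnRH Antagonist

The source may hold more compounds than are shown below. What is called first, only, known or untested is meant among the compounds shown, and "the series" means these compounds.

Compound 1, `COc1cccc(-c2c(C)n(Cc3c(F)cccc3F)c(=O)n(C[C@H](CO)NC3CCCC3)c2=O)c1F`: 4.9 nM
Compound 2, `COc1cccc(-c2c(C)n(Cc3c(F)cccc3C(F)(F)F)c(=O)n(C[C@H](C)NC3CCCC3)c2=O)c1`: 4.5 nM
Compound 3, `CC[C@@H](Cn1c(=O)c(-c2cccc(OC)c2Cl)c(C)n(Cc2c(F)cccc2C(F)(F)F)c1=O)NC1CCCC1`: 3.7 nM

The read-out throughout is an assay on isolated protein for binding affinity to Gonadotropin-releasing hormone receptor (Homo sapiens); on this read-out higher numbers stand for weaker inhibition and lower numbers for stronger inhibition. In this assay compound 1 gives 4.9 nM, compound 2 gives 4.5 nM, and compound 3 gives 3.7 nM. Compound 3 carries the lowest of the three numbers, but its gaps to compound 2 and to compound 1 both lie within the usual scatter of repeated measurements, so the three compounds cannot be ranked against one another on these numbers alone.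

Compound 4, `CC[C@H](Cn1c(=O)c(-c2cccc(OC)c2Cl)c(C)n(Cc2c(F)cccc2C(F)(F)F)c1=O)NC1CCCC1`, has not yet been measured. It differs from compound 3 as follows: the two compounds have the same atoms and bonds and differ only in configuration as drawn: 1 of 1 stereo elements differ; a stereocentre at a saturated chain carbon is drawn S in compound 3 and R in compound 4. Nothing leaves and nothing enters; only the spatial arrangement at that one chain carbon is reversed.

Among the compounds with values here, no measured pair in this set differs by a change of configuration alone, so the data give no direct guide to the size of such a step. All three measured compounds share the same drawn arrangement at the corresponding centre, and all three sit close together in this assay. Reversing that arrangement is expected to weaken binding, by a step of an 11-fold higher number from compound 3 to compound 4 (1.03 log units; beyond the scatter), though with considerable uncertainty. Compound 4 is therefore estimated at 40 nM, within a range from 4 nM to 400 nM.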

Compound 4, inhibition constant: 7.4 nM
Compound 4: the middle estimate sits 5.4-fold (0.73 log units) above what was measured, and the stated range covers the measured number.
By their numbers in this assay, from the lowest: compounds 3, 2, 1 and 4 (each within the scatter of the next).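

Within the data shown here, compounds 3 and 4 are the first pair here separated by nothing but the spatial arrangement at one chain carbon, so the size of this change can now be read directly rather than inferred. In this assay, reversing that centre gives a 2.0-fold higher number from compound 3 to compound 4 (0.30 log units; within the scatter), which means that the drawn S and drawn R forms cannot be told apart on these numbers, and that for this pair the reversal leaves no mark larger than repeated measurements alone could produce. Whatever gap exists between the two can be traced only to that one carbon, because nothing else separates them: the fact that compounds 3 and 4 differ only in the configuration as drawn

This single pair cannot show whether the same reversal would give a step of similar size in compounds with a different group on that chain carbon, such as a carboxylic acid or a longer chain, or with the cyclopentyl group on the nitrogen replaced by a simple methyl group. It also leaves open whether the two mirror-image arrangements would remain indistinguishable in a read-out other than this binding measurement on isolated protein.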